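The source may hold more compounds than are shown below. What is called first, only, known or untested is meant among the compounds shown, and "the series" means these compounds.

Measured so far in a functional assay on SMMC-7721 cells (Homo sapiens) for antiproliferative activity, read by MTT assay, with a stated time of 72 h; on this read-out lower numbers stand for stronger inhibition and higher numbers for weaker inhibition 
- Compound 1 `CN(C(=O)C(C)(C)C)c1ccc2[nH]c(-c3n[nH]c4ccccc34)cc2n1` gives 22200 nM 
- Compound 2 `CN(C(=O)c1ccccc1)c1ccc2[nH]c(-c3n[nH]c4ccccc34)cc2n1` gives 12500 nM 
- Compound 3 `CN(C(=O)c1ccc(F)cc1)c1ccc2[nH]c(-c3n[nH]c4ccccc34)cc2n1` gives 9150 nM 

Compound 3 stands at 9150 nM on this scale. It is clearly lower than one neighbour (a 2.4-fold lower number from compound 1 to compound 3 (0.38 log units; beyond the scatter)) and level with the other (a 1.4-fold lower number from compound 2 to compound 3 (0.14 log units; within the scatter)).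

Compound 4 `CN(C(=O)c1ccc([N+](=O)[O-])cc1)c1ccc2[nH]c(-c3n[nH]c4ccccc34)cc2n1` has not been measured yet. It carries nitro in place of fluoro on an aromatic carbon, para to a large group (nitro in place of fluoro on an aromatic carbon).

The closest guide is the fluoro in place of hydrogen on an aromatic carbon, which made little difference to compound 3 (a 1.4-fold lower number from compound 2 to compound 3 (0.14 log units; within the scatter)). Phenyl in place of tert-butyl on a carbonyl carbon also stayed small in compound 2 (a 1.8-fold lower number from compound 1 to compound 2 (0.25 log units; within the scatter)). Among the compounds with values here, no measured compound carries a nitro group, so these steps give no direction, and no change beyond the scatter is expected in this assay here.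

The estimated step is small (a 1.1-fold lower number from compound 3 to compound 4 (0.03 log units; within the scatter)) and rests on little data. For compound 4 the estimated value is 8500 nM, with an expected range from 3500 nM to 20000 nM in this read-out.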

Compound 4, half-maximal inhibitory concentration: 18400 nM
Beside the measured number, compound 4's estimate is 2.2-fold (0.34 log units) below it, and the stated range covers the measured number.
By their numbers in this assay, from the lowest: compounds 3, 2, 4 and 1 (each within the scatter of the next, the first and the last beyond it).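

In this assay a much larger group than fluoro can sit at this position without a change beyond the scatter: nitro, with its 3 heavy atoms and 2 hydrogen-bond acceptors, gives (a 2.0-fold higher number from compound 3 to compound 4 (0.30 log units; within the scatter)) when it replaces fluoro and (a 1.5-fold higher number from compound 2 to compound 4 (0.17 log units; within the scatter)) when it replaces hydrogen. The 4-nitrophenyl group also differs from tert-butyl only within the scatter (a 1.2-fold lower number from compound 1 to compound 4 (0.08 log units; within the scatter)), so the gap beyond the scatter seen from compound 1 to compound 3 does not carry over to compound 4, and the position has so far tolerated fluoro, hydrogen and nitro about equally. No measurement at hand offers a reason for this.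

On these data alone, whether an amine or a carboxylic acid in this same place would move the number beyond the scatter remains open. So does whether a longer chain in place of tert-butyl on the carbonyl would do so.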